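The source may report more compounds than this note shows. Statements on the series, on what has been measured and on what is new or still open speak of the compounds shown alone.

Three compounds share one core and differ only in the group attached through an oxygen on an aromatic ring. In a functional assay on mitochondria (Cricetulus griseus) for inhibition of Monoamine oxidase (Homo sapiens), tested at 3 uM (a lower number here means a weaker effect, a higher number a stronger effect of the compound at the concentration tested), compound 1 `CCOc1ccc2c(=O)c(-c3ccc(O)cc3)coc2c1` gives 95.6%, compound 2 `O=c1c(-c2ccc(O)cc2)coc2cc(OCCC3OCCCO3)ccc12` gives 75.3%, and compound 3 `C=CCOc1ccc2c(=O)c(-c3ccc(O)cc3)coc2c1` gives 89.3%. Compound 3 stands second highest of the three: a number 6.3 percentage points lower from compound 1 to compound 3 (within the scatter), while a number 14 percentage points higher from compound 2 to compound 3 (beyond the scatter). Compound 4 `O=C(O)CCCCCCOc1ccc2c(=O)c(-c3ccc(O)cc3)coc2c1` carries a much longer chain, namely (5-carboxypentyl in place of vinyl on a saturated chain carbon bound to an oxygen on an aromatic ring). The step that bears on this is a number 20.3 percentage points lower from compound 1 to compound 2 (beyond the scatter), where a larger group placed out along the chain went with weaker inhibition. A modest lowering of similar size is therefore expected for compound 4, so that a number 13.3 percentage points lower from compound 3 to compound 4 (beyond the scatter). Compound 4 is expected to give 76%, estimated to fall between 60% and 92%.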

Compound 4, a percentage reported as inhibition, at one concentration (the size of the read-out at that concentration, not a potency): 87.4%
Estimate against measurement, compound 4: 11.4 percentage points below, within the range that was stated.
By their numbers in this assay, from the lowest: compound 2; then compounds 4, 3 and 1 (each within the scatter of the next).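

In this assay, a long chain ending in a carboxylic acid fits at this position with no change beyond the scatter: 5-carboxypentyl in place of vinyl gives a number 1.9 percentage points lower from compound 3 to compound 4 (within the scatter), and the comparison with compound 1 gives a number 8.2 percentage points lower from compound 1 to compound 4 (within the scatter). Chain size alone therefore does not go with a lower number, since compound 4 carries a larger group without a ring, and a number 12.1 percentage points higher from compound 2 to compound 4 (beyond the scatter).

On these data alone, whether an amine at the end of the same chain would give a similar number remains open, as does whether the ring of compound 2 goes with its lower number. Nothing available explains these results.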